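Aryl swap on the triazole of a bromophenol series

The compounds below may be only part of what the source reports. "The series", "measured", "known", "first", "only" and "open" are said of these compounds alone.

Compound 1 `COc1ccc(-c2cn(C[C@H]3c4c(ccc(O)c4C)[C@@H]4CC[C@@]5(C)C[C@]43CC5=O)nn2)cc1` and compound 2 `C=C1C[C@]23C[C@@]1(O)CC[C@H]2c1cc(Br)c(O)c(C)c1[C@@H]3Cn1cc(-c2ccccn2)nn1` are the two members of this set tested so far, both in a functional assay on SW480 cells (Homo sapiens) for cytotoxicity, read by MTT assay, with a stated time of 4 days; on this read-out higher numbers stand for weaker inhibition and lower numbers for stronger inhibition. Compound 1 returns only the limit of the assay, > 20000 nM. Compound 2 likewise returns only a limit, > 20000 nM. Among the measured compounds shown here, compound 2 therefore stands nowhere on a numerical scale: both values shown sit at the limit of > 20000 nM in this assay, at which 2 of the 2 values shown sit, and no step between measured compounds can be drawn from this pair.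

Compound 3 `C=C1C[C@]23C[C@@]1(O)CC[C@H]2c1cc(Br)c(O)c(C)c1[C@@H]3Cn1cc(-c2ccc(Cl)cc2)nn1` is the next candidate for this assay. It differs from compound 2 in a single place: 4-chlorophenyl in place of pyridin-2-yl on an aromatic carbon. The rest of the shared core, with its bromine, phenol and methylene-bearing ring, is unchanged.

With no measured step available, the expectation for compound 3 rests only on the values already shown. Because compound 2 gives > 20000 nM in this assay, no move beyond the scatter is expected from this aryl swap, in either direction. Compound 3 is expected to give about 30000 nM in this assay, with a range from 8000 nM to 120000 nM, a step that the limit leaves unreadable from compound 2 to compound 3 that would most likely again be reported as a limit.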

Compound 3, half-maximal inhibitory concentration: 18000 nM
Beside the measured number, compound 3's estimate is 1.7-fold (0.22 log units) above it; the range from low to high includes it.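

In this assay, among the compounds shown here, compound 3 gives 18000 nM, the first value in this set that is a number and not a limit, so this aromatic carbon of the five-membered ring can bear a group that leaves a readable value on the shared core. Setting 4-chlorophenyl in place of pyridin-2-yl gives an at least 1.1-fold lower number from compound 2 to compound 3 (0.04 log units; that floor lies within the scatter), so only a floor is available, and that floor does not establish a real difference between the two aryl groups. The true size of the step stays unknown because one end of it is a limit: the limit of > 20000 nM in this assay, at which 2 of the 3 values shown sit.

Still open, from the compounds shown here alone, is whether the chlorine or the carbon-only ring goes with the readable value in compound 3, a question that an unsubstituted phenyl, or a phenyl bearing an amine or a carboxylic acid, in the same place would help to answer. Compound 1 differs from compound 3 in more than one place and so offers no comparison, which leaves the effect of this aryl swap on any other core unknown.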